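A few compounds are considered here, and "the series" means these few. Any claim that something is new, unique, unknown or untested is made for them only; others in the source may bear on it.

Compound 1 `COc1ccc(F)cc1CNCCCNc1ccnc2cc(Cc3cccc(C(F)(F)F)c3)ccc12` was measured in a physicochemical assay for solubility, with a stated time of 18 h, at pH 7.4 (a higher number here means a more soluble compound, a lower number a less soluble compound), where compound 1 gives 4200 nM. Compound 2 `FC(F)(F)c1cccc(Cc2ccc3c(NCCCNCc4ccco4)ccnc3c2)c1` gives 4200 nM in this assay, and the measured step of no change at the digits printed from compound 1 to compound 2 (within the scatter) leaves compound 1 level with compound 2. Compound 3 `COc1ccc(F)cc1CNCCCNc1ccnc2cc(-c3ccccc3)ccc12` differs from compound 1 by phenyl in place of 3-(trifluoromethyl)benzyl on an aromatic carbon. For the measured compounds named here, the one measured step alters a different part of the shared core, so no measured step bears on this change. Compound 3 is therefore expected to show at most a small rise, a 1.4-fold higher number from compound 1 to compound 3 (0.15 log units; within the scatter), or none beyond the scatter. The estimate for compound 3 is 6000 nM, within 2500 nM to 15000 nM.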

Compound 3, solubility: 32000 nM
Estimate against measurement, compound 3: 5.3-fold (0.73 log units) below, outside the stated range (above it).
By their numbers in this assay, from the lowest: compounds 1 and 2 (each within the scatter of the next); then compound 3.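

This position on the shared core matters in this assay: with phenyl in place of 3-(trifluoromethyl)benzyl on this aromatic carbon, the result is a 7.6-fold higher number from compound 1 to compound 3 (0.88 log units; beyond the scatter). The earlier step, which altered a different part of the molecule, showed no change beyond the scatter. No measurement shown here explains the rise.

The change removes both the trifluoromethyl group and the benzyl carbon, so this one step cannot separate their contributions. As far as these compounds go, whether plain benzyl, 3-(trifluoromethyl)phenyl or a pyridine ring at this position would give a similar number remains open.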